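Adding Trifluoromethyl to the Benzyl Group of Compound 2

The source may report more compounds than this note shows. Statements on the series, on what has been measured and on what is new or still open speak of the compounds shown alone.

Within the data shown here, compound 2 `CC(C)n1ncc2c(C(=O)NCc3cn(Cc4ccccc4)nn3)cccc21` is the one member of this pair with a numerical result. In a functional assay on MCF7 cells (Homo sapiens) for inhibition, read by MTT assay, with a stated time of 72 h (on this read-out lower numbers stand for stronger inhibition and higher numbers for weaker inhibition), compound 2 gives 9170 nM. Compound 1 `Cc1ccccc1-n1cc(CNC(=O)c2cccc3c2cnn3C(C)C)nn1` reaches only a limit of the assay: in this assay compound 1 gives > 40000 nM. Among the measured compounds shown here, the single measured step, an at least 4.3-fold lower number from compound 1 to compound 2 (0.63 log units; beyond the scatter), changes the group on the aromatic nitrogen, and its size is bounded by the limit of > 40000 nM in this assay, at which 1 of the 2 values shown sits. Compound 3 `CC(C)n1ncc2c(C(=O)NCc3cn(Cc4ccc(C(F)(F)F)cc4)nn3)cccc21` differs from compound 2 by trifluoromethyl in place of hydrogen on an aromatic carbon, which cut one bond further out reads phenyl to 4-(trifluoromethyl)phenyl. For the measured compounds named here, no measured step alters a substituent on that six-membered aromatic ring of carbon only, so the measured step bears on the change only loosely. For compound 3 in this assay a step of a 1.3-fold lower number from compound 2 to compound 3 (0.12 log units; within the scatter) is expected, not beyond the scatter. Compound 3 is estimated at 7000 nM, between 2500 nM and 25000 nM.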

Compound 3, half-maximal inhibitory concentration: > 40000 nM
Compound 3: a limit, no number; the forecaster's own chance of this, stated with the estimate: 20%; middle value at least 5.7-fold (0.75 log units) from the limit.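

Among these compounds, until now no measured step had altered a substituent on the six-membered aromatic ring of the benzyl group; the change at this position now reads in this assay as an at least 4.3-fold higher number from compound 2 to compound 3 (0.63 log units; beyond the scatter), so trifluoromethyl in place of hydrogen here does not leave the result in place. Compound 3 gives > 40000 nM, which is a limit of the assay and not a number. The step is therefore bounded on one side only, and its full size stays unknown: the limit of > 40000 nM in this assay, at which 2 of the 3 values shown sit.

The compounds shown leave open whether a single fluorine atom, a methyl group, an amine or a carboxylic acid at the same place would hold the level of compound 2. They also leave open whether trifluoromethyl on another carbon of that ring would read the same way.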